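Pyrazoline sulfonamide series: aryl swap on the saturated ring carbon

A few compounds are considered here, and "the series" means these few. Any claim that something is new, unique, unknown or untested is made for them only; others in the source may bear on it.

Measured so far:
compound 1 `COc1cc(C)c(Cl)cc1C1=NN(c2ccc(S(N)(=O)=O)cc2)C(c2cccc(O)c2)C1` 39.5%
compound 2 `COc1cc(C)c(Cl)cc1C1=NN(c2ccc(S(N)(=O)=O)cc2)C(c2ccc(N(C)C)cc2)C1` 78.9%

Compound 2 gives the higher of the two numbers in a functional assay on the whole organism (strain Wistar) for inhibition, with Rattus norvegicus as the target, read by paw edema, with stated times of 30 min and 3 h, at a dose of 20 mg/kg by the oral route; on this read-out lower numbers stand for less inhibition and higher numbers for more inhibition at the one dose given (going by the name of the read-out); the step of a number 39.4 percentage points higher from compound 1 to compound 2 (beyond the scatter) is large and beyond the scatter, so compound 2 stands clearly above compound 1.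

Compound 3 `COc1ccc(C2CC(c3cc(Cl)c(C)cc3OC)=NN2c2ccc(S(N)(=O)=O)cc2)cc1OC` is not yet measured. It differs from compound 2 by 3,4-dimethoxyphenyl in place of 4-(dimethylamino)phenyl on a saturated ring carbon. Within the data shown here, no measured step covers a 3,4-dimethoxyphenyl group; the only step in hand, a number 39.4 percentage points higher from compound 1 to compound 2 (beyond the scatter), concerns the same saturated ring carbon but exchanges 3-hydroxyphenyl for 4-(dimethylamino)phenyl, and it shows that a change of the aryl group at that carbon can move the read-out far beyond the scatter. Whether a move toward the level of compound 1 or retention of the level of compound 2 follows cannot be read from these two points.

Compound 3 is therefore expected to fall between the two measured values, estimated at 60% with a range of 38% to 82%. This estimate means a step of a number 18.9 percentage points lower from compound 2 to compound 3 (beyond the scatter), expected to be downward and of moderate size, but with wide uncertainty.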

Compound 3, a percentage reported as inhibition, in the whole organism at one dose (the size of the read-out at that dose, not a potency): 31.6%
Compound 3: middle estimate off by 28.4 percentage points, on the high side, and the stated range ends above it.
By their numbers in this assay, from the lowest: compounds 3 and 1 (each within the scatter of the next); then compound 2.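

The step of a number 47.3 percentage points lower from compound 2 to compound 3 (beyond the scatter) in this assay shows that the high level of compound 2 does not carry over to every substituted phenyl group on this saturated ring carbon, next to the ring nitrogen. The step of a number 7.9 percentage points lower from compound 1 to compound 3 (within the scatter) puts 3,4-dimethoxyphenyl and 3-hydroxyphenyl at one level in this assay, so among the three aryl groups shown, only 4-(dimethylamino)phenyl stands apart, and it does so beyond the scatter against both others. Nothing available on properties or mechanism bears on why these aryl groups separate in this way.

The compounds shown leave open whether the level of compound 2 depends on the dimethylamino group itself or would also be reached with another substituent on that phenyl ring, a question that a 4-methoxyphenyl or a 4-(diethylamino)phenyl group on the same saturated ring carbon would help to settle. From the compounds shown here alone, since each number belongs to a single oral dose, it also stays open how far the separation between compound 2 and the other two compounds would hold at other doses.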